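The source may hold more compounds than are shown below. What is called first, only, known or untested is meant among the compounds shown, and "the series" means these compounds.

Measured compounds and their values:

compound 1 `Cc1ccc(Nc2nccc(-c3ccnc4ccccc34)n2)cc1`, in a functional assay on PC-3 cells (Homo sapiens) for cytotoxicity, read by sulforhodamine B assay, with a stated time of 48 h, tested at 50 uM (a higher number here means more inhibition at the concentration tested (going by the name of the read-out), a lower number less inhibition), compound 1 gives 100%
compound 2 `FC(F)(F)c1ccc(Nc2nccc(-c3cnc4ccccc4c3)n2)cc1`, in this assay compound 2 gives 22.9%
compound 3 `Nc1nccc(-c2cnc3ccccc3c2)n1`, in this assay compound 3 gives 31.9%

Compound 3 stands second highest of the three numbers. Its nearest neighbour is compound 2, whose value lies within the scatter of it, so nothing can be said about order between these two. Compound 1 stands far above both, beyond the scatter.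

Compound 4 `Cc1ccc(Nc2nccc(-c3cnc4ccccc4c3)n2)cc1` is not yet measured. It differs from compound 3 in one place: 4-methylphenyl in place of hydrogen on a nitrogen on an aromatic ring. Cut one bond further out, the change reads amino to (4-methylphenyl)amino. Compound 1 carries the same (4-methylphenyl)amino group on a differently joined core and gives a high value, while compound 2, with another substituted phenyl on the core of compound 3, gives a value within the scatter of compound 3. An upward step in this assay is therefore expected, but of uncertain size, and a step no larger than the scatter cannot be ruled out.

For compound 4 the estimate in this assay is 48%, with a range from 18% to 90%, meaning an expected step of a number 16.1 percentage points higher from compound 3 to compound 4 (beyond the scatter).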

Compound 4, a percentage reported as inhibition, at one concentration (the size of the read-out at that concentration, not a potency): 59.5%
For compound 4 the middle estimate is 11.5 percentage points below the measured one, within the range that was stated.
By their numbers in this assay, from the lowest: compounds 2 and 3 (each within the scatter of the next); then compound 4; then compound 1.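

In this assay, 4-methylphenyl in place of hydrogen on a nitrogen on an aromatic ring gives a real gain on this core, a number 27.6 percentage points higher from compound 3 to compound 4 (beyond the scatter). The added ring alone does not account for this gain: methyl in place of trifluoromethyl on an aromatic carbon gives a number 36.6 percentage points higher from compound 2 to compound 4 (beyond the scatter), while compound 2 lies within the scatter of compound 3, so the outcome here depends on the group carried by the phenyl ring. The data shown give no measured explanation for either step.

The compounds shown leave open how a methoxy group, a chlorine atom or an amine would compare with methyl on that aromatic carbon. They also leave open whether a longer chain in place of methyl would keep the value of compound 4.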